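Butyl for ethyl on the shared core: an expectation

The source may report more compounds than this note shows. Statements on the series, on what has been measured and on what is new or still open speak of the compounds shown alone.

Three compounds have been run in a functional assay on K562 cells (Homo sapiens) for inhibition, read by MTT assay, with a stated time of 72 h; on this read-out higher numbers stand for weaker inhibition and lower numbers for stronger inhibition. Compound 1 `CCc1ccc(C(=O)/C=C/C(=O)O)cc1` gives 5530 nM; compound 2 `Cc1cc(C2CCCCC2)c(C)cc1C(=O)/C=C/C(=O)O` gives 4240 nM; compound 3 `CCc1cc(CC)c(C(=O)/C=C/C(=O)O)c(CC)c1` gives 4010 nM. Compound 1 stands within the scatter of both others: neither gap reaches beyond the usual repeat variation, so no order among the three is established. Compound 4 `CCCCc1ccc(C(=O)/C=C/C(=O)O)cc1` has not yet been measured in this assay. It differs from compound 1 by ethyl in place of hydrogen on a saturated chain carbon, two bonds along the chain from an aromatic carbon. Within the data shown here, no measured pair shows this step, and the values of compound 1, compound 2 and compound 3 give no sign that going from ethyl to butyl moves the read-out, so the step of a 1.2-fold lower number from compound 1 to compound 4 (0.09 log units; within the scatter) is expected to stay within the scatter. Compound 4 is estimated at 4500 nM, with a range from 2000 nM to 10000 nM.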

Compound 4, half-maximal inhibitory concentration: 4950 nM
The estimate for compound 4 lay 1.1-fold (0.04 log units) below the measured number; the range from low to high includes it.
By their numbers in this assay, from the lowest: compounds 3, 2, 4 and 1 (each within the scatter of the next).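

In this assay the first measured case of this change reads a 1.1-fold lower number from compound 1 to compound 4 (0.05 log units; within the scatter) and so, at this position on the shared core, the chain can go from ethyl to butyl with no shift that stands clear of repeat variation. This holds for this one pair only. Nothing available explains the result.

From the compounds shown here alone, whether a longer chain such as hexyl, or an amine at the chain end, would move the read-out beyond the scatter remains open. So does whether the same change behaves alike on the cores of compound 2 and compound 3.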